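Replacing the (4-ethoxyphenyl)amino group of compound 3

A few compounds are considered here, and "the series" means these few. Any claim that something is new, unique, unknown or untested is made for them only; others in the source may bear on it.

Compound 1 `C#CCCOC(=O)c1ccc(C(CC)(CC)c2ccc(OCCC(O)(CC)CC)c(C)c2)n1CC`: > 50000 nM (a limit)
Compound 2 `CCn1c(C(=O)Nc2ccc(OC(F)(F)F)cc2)ccc1C(CC)(CC)c1ccc(OCCC(O)(CC)CC)c(C)c1`: > 50000 nM (a limit)
Compound 3 `CCOc1ccc(NC(=O)c2ccc(C(CC)(CC)c3ccc(OCCC(O)(CC)CC)c(C)c3)n2CC)cc1`: > 50000 nM (a limit)
Compound 4 `CCn1c(C(=O)N(C)CC(=O)O)ccc1C(CC)(CC)c1ccc(OCCC(O)(CC)CC)c(C)c1`: not yet measured

In a functional assay on HepG2 cells (Homo sapiens) for antiproliferative activity, read by MTT assay, with a stated time of 48 h (a higher number here means a weaker inhibitor, a lower number a stronger inhibitor), compound 3 gives > 50000 nM, which is a limit of the assay and not a number. It shares this position with the other measured compounds, as the record shows: the limit of > 50000 nM in this assay, at which 3 of the 3 values shown sit.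

Compound 4 carries (carboxymethyl)(methyl)amino in place of (4-ethoxyphenyl)amino on a carbonyl carbon.

Going by the values given here, three measured steps bear on this change, two of them at the same carbonyl carbon: a step that the two limits leave unreadable from compound 1 to compound 2, a step that the two limits leave unreadable from compound 1 to compound 3 and a step that the two limits leave unreadable from compound 2 to compound 3. None of them has a readable size, so they offer no measured shift to carry over. In this assay, no change beyond the scatter is therefore expected, and no direction can be assigned.

The expected change is a step that the limit leaves unreadable from compound 3 to compound 4.

For compound 4 the estimate is 60000 nM, with an expected range of 30000 nM to 120000 nM.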

Compound 4, half-maximal inhibitory concentration: 5710 nM
Compound 4: the middle estimate sits 11-fold (1.02 log units) above what was measured; the measured number lies below the stated range.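

In this assay, going by these compounds alone, (carboxymethyl)(methyl)amino on the carbonyl carbon gives an at least 8.7-fold lower number from compound 3 to compound 4 (0.94 log units; beyond the scatter), the first step at this position that can be read, as the earlier steps among compounds 1, 2 and 3 cannot. The same group gives an at least 8.7-fold lower number from compound 2 to compound 4 (0.94 log units; beyond the scatter) and an at least 8.7-fold lower number from compound 1 to compound 4 (0.94 log units; beyond the scatter), so all three earlier groups at this carbonyl carbon lead to the same lower bound. The position can therefore move the read-out off the limit, and compound 4 alone among the four has done so: the limit of > 50000 nM in this assay, at which 3 of the 4 values shown sit.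

As far as these compounds go, how large these steps really are stays open, since each starts from a limit. Also open, from the compounds shown here alone, is which part of the entering group matters: a methyl ester in place of the carboxylic acid, a hydrogen in place of the nitrogen's methyl, or a longer chain to the carboxylic acid would test this.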